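The compounds below may be only part of what the source reports. "The series", "measured", "known", "first", "only" and "open" are said of these compounds alone.

compound 1 `Cc1c(Cc2ccccc2)c(NNC(=O)Nc2cc(Cl)nc(Cl)c2)nc2c1cnn2C` gives 21400 nM
compound 2 `COc1cc(NC(=O)NNc2cc(-c3ccccc3)c3cnn(C)c3n2)cc(Cl)n1` gives 28700 nM
compound 3 `Cn1ncc2c(-c3ccc(F)cc3)cc(NNC(=O)Nc3cc(Cl)cc(Cl)c3)nc21` gives 54300 nM

All three numbers come from a functional assay on SW620/5-FU cells (Homo sapiens) for cytotoxicity, read by MTT assay, with a stated time of 48 h, in the presence of a further agent that is not named here; a higher number here means that more compound is needed for the effect, a lower number that less compound is needed. Compound 2, at 28700 nM, lies within the usual scatter of both compound 1 and compound 3, so it cannot be separated from either of them.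

The next compound to be tested is compound 4 `Cn1ncc2c(-c3ccccc3)cc(NNC(=O)Nc3cc(Cl)nc(Cl)c3)nc21`. It differs from compound 2 at a single place, with chloro in place of methoxy on an aromatic carbon. Among the compounds with values here, no two measured compounds differ in only one place, so no measured step shows what this change does. The closest guide is compound 1, which carries the same 2,6-dichloropyridin-4-yl group on a different core and gives 21400 nM. This value lies within the scatter of compound 2, so no shift beyond the scatter is expected. The estimated change is a 1.1-fold lower number from compound 2 to compound 4 (0.06 log units; within the scatter). For compound 4 the expected value is 25000 nM, with an estimated range from 10000 nM to 60000 nM.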

Compound 4, half-maximal effective concentration: 76900 nM
For compound 4 the middle estimate is 3.1-fold (0.49 log units) below the measured one; the whole stated range lies below it.
By their numbers in this assay, from the lowest: compounds 1, 2, 3 and 4 (each within the scatter of the next, the first and the last beyond it).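

Within the data shown here, this is the first step in this assay that changes one place only. Putting chloro in place of methoxy on the aromatic carbon next to the ring nitrogen gives a 2.7-fold higher number from compound 2 to compound 4 (0.43 log units; beyond the scatter) and so turns the 2-chloro-6-methoxypyridin-4-yl group into the 2,6-dichloropyridin-4-yl group, with more compound needed for the effect. The step is modest but lies beyond the usual scatter, which shows that this position responds to a change of group, and nothing measured here explains the shift.

Among these compounds, only this one pair carries the change, so whether it would run the same way on another core remains open. Also open, on these data alone, is how a small amine, a hydroxyl group or a plain methyl group would behave at this position.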